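The compounds below may be only part of what the source reports. "The series", "measured", "known", "first", "only" and "open" are said of these compounds alone.

Going by the values given here, compound 2 `O=C(Nc1c(C(O)(C(F)(F)F)C(F)(F)F)ccc2ccccc12)c1ccc(F)cc1` carries an aromatic amide on a shared core, and in an assay on LtK cells with ATP-sensitive inward rectifier potassium channel 11 (Homo sapiens) as the target (on this read-out higher numbers stand for an effect only at larger amounts of compound and lower numbers for an effect already at smaller amounts), compound 2 gives 70 nM, the lowest of the two numbers measured so far. Its nearest neighbour is compound 1 `O=C(Nc1c(C(O)(C(F)(F)F)C(F)(F)F)ccc2ccccc12)C1CC1`, which has a cyclopropyl group on the carbonyl carbon instead; in this assay compound 1 gives 751 nM. Among the compounds with values here, the single measured step, an 11-fold lower number from compound 1 to compound 2 (1.03 log units; beyond the scatter), shows that the group on the carbonyl carbon matters a great deal on this read-out.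

Compound 3 `O=C(Nc1c(C(O)(C(F)(F)F)C(F)(F)F)ccc2ccccc12)c1ccc(C(F)(F)F)cc1` keeps the aromatic amide of compound 2 and changes only its far end: trifluoromethyl in place of fluoro on an aromatic carbon. Within the data shown here, no measured step touches that position; the step from compound 1 to compound 2 concerns the exchange of a whole ring for a small non-aromatic group, which is a different kind of change. Since the aromatic ring that gave the large gain is kept, compound 3 is expected to stay near compound 2, with a step of a 1.3-fold lower number from compound 2 to compound 3 (0.10 log units; within the scatter) that may well fall within the scatter. Compound 3 is therefore estimated at 55 nM, within a range from 15 nM to 200 nM.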

Compound 3, half-maximal effective concentration: 160 nM
For compound 3 the middle estimate is 2.9-fold (0.46 log units) below the measured one; the range from low to high includes it.
By their numbers in this assay, from the lowest: compound 2; then compound 3; then compound 1.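

In this assay the far end of the aromatic amide proves to be a position that responds, even with the ring itself kept: trifluoromethyl in place of fluoro gives a 2.3-fold higher number from compound 2 to compound 3 (0.36 log units; beyond the scatter). The change is modest, but it means the gain seen with the aromatic ring can be partly lost through a single group on that ring. The ring with trifluoromethyl still compares well with cyclopropyl on the carbonyl carbon, at a 4.7-fold lower number from compound 1 to compound 3 (0.67 log units; beyond the scatter), so both aromatic amides shown give lower numbers than compound 1, and neither goes against that pattern within these three compounds. No measurement at hand speaks to what lies behind the difference between fluoro and trifluoromethyl.

With only two groups at this position, the compounds shown cannot separate the effect of the four heavy atoms of trifluoromethyl from that of any other difference between the two groups. From the compounds shown here alone, how a methoxy group, an amine or a carboxylic acid in the same place would compare remains open, as does whether an unsubstituted phenyl would give a lower number than compound 2.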